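A few compounds are considered here, and "the series" means these few. Any claim that something is new, unique, unknown or untested is made for them only; others in the source may bear on it.

Three urea compounds have been measured in an in vitro functional assay on cells for antagonist activity at transient receptor potential cation channel subfamily V member 1 (Homo sapiens), read by reporter gene assay and calcium flux; on this read-out lower numbers stand for stronger inhibition and higher numbers for weaker inhibition. Compound 1 `O=C(Nc1ccc(Cl)c(C(F)(F)F)c1)Nc1cccc2c(O)cccc12` gives 45 nM in this assay, and compound 2 `O=C(Nc1ccc(Cl)c(C(F)(F)F)c1)Nc1cccc2ccc(O)c(F)c12` gives 9.1 nM. Compound 3 `NS(=O)(=O)Cc1ccccc1NC(=O)Nc1ccc(Cl)c(C(F)(F)F)c1` gives 460 nM, which is the highest of the three numbers: the number for compound 3 lies beyond the usual scatter above that of compound 1, and much further above that of compound 2. Compound 4 `O=C(Nc1ccc(Cl)c(C(F)(F)F)c1)Nc1ccccc1CO` has not been measured yet. It differs from compound 3 in one place: hydroxy in place of sulfamoyl on a saturated chain carbon bound to an aromatic carbon. For the measured compounds named here, no measured pair shows the same change, so the size of the step is uncertain. Because compound 3 gives 460 nM and the groups that sit on a saturated chain carbon bound to an aromatic carbon are both hydrogen-bond donors and acceptors, the expectation is a step of a 1.1-fold higher number from compound 3 to compound 4 (0.04 log units; within the scatter) that stays near the scatter, with no strong change in either direction. The estimate for compound 4 in this assay is 500 nM, expected to fall between 150 nM and 1600 nM.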

Compound 4, half-maximal inhibitory concentration: 330 nM
Estimate against measurement, compound 4: 1.5-fold (0.18 log units) above; the range from low to high includes it.
By their numbers in this assay, from the lowest: compound 2; then compound 1; then compounds 4 and 3 (each within the scatter of the next).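

In this assay the swap of sulfamoyl for hydroxy on a saturated chain carbon bound to an aromatic carbon gives a 1.4-fold lower number from compound 3 to compound 4 (0.14 log units; within the scatter) and is the first one-place comparison among these compounds. At this position, the read-out does not separate the two groups, even though hydroxy has 1 heavy atom and sulfamoyl has 4, so the smaller group serves as well as the larger one here. No measurement at hand offers a reason for this match.

From the compounds shown here alone, it remains open whether an amine or a carboxylic acid on the same carbon, or a longer chain in place of hydroxymethyl, would give a clearly different number. Also open, going by these compounds, is whether the same swap would stay as small on the core of compound 2.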